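Chain length at the arylamine: compound 3 estimate

The compounds below may be only part of what the source reports. "The series", "measured", "known", "first", "only" and "open" are said of these compounds alone.

Measured so far:
compound 1 `CCCCCCCCNc1ccc(C(=O)O)cc1S(=O)(=O)N(C)C`: 70.6%
compound 2 `COCCNc1ccc(C(=O)O)cc1S(=O)(=O)N(C)C`: 4.1%

Compound 2 stands lowest of the two numbers in hand; its nearest neighbour is compound 1, which lies higher by a number 66.5 percentage points lower from compound 1 to compound 2 (beyond the scatter) read in the opposite direction, a gap well beyond the scatter.

Compound 3 `COCCCCNc1ccc(C(=O)O)cc1S(=O)(=O)N(C)C` is the next member. It differs from compound 2 by 2-methoxyethyl in place of methoxy on a saturated chain carbon, two bonds along the chain from a nitrogen on an aromatic ring.

Among the measured compounds shown here, the only measured step that bears on this change is a number 66.5 percentage points lower from compound 1 to compound 2 (beyond the scatter), a large loss when the octyl-type chain was cut back to the short methoxy-terminated chain. Compound 3 moves partway back toward compound 1 in chain length while keeping the ether oxygen, so in an assay on HEK293 cells for inhibition of solute carrier family 12 member 2 (Homo sapiens), read by fluorescence, with a stated time of 30 min, tested at 100 uM (on this read-out lower numbers stand for a weaker effect and higher numbers for a stronger effect at the one concentration tested), a moderate gain over compound 2 is expected, short of the full return to compound 1 and not assured to clear the scatter.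

For compound 3 the expected step is a number 20.9 percentage points higher from compound 2 to compound 3 (beyond the scatter). Compound 3 is estimated at 25%, with a range from 4% to 55%.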

Compound 3, a percentage reported as inhibition, at one concentration (the size of the read-out at that concentration, not a potency): 5.2%
For compound 3 the middle estimate is 19.8 percentage points above the measured one; the measured number falls inside the stated range.
By their numbers in this assay, from the lowest: compounds 2 and 3 (each within the scatter of the next); then compound 1.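

Working from the methoxy-terminated chain in this assay, 2-methoxyethyl in place of methoxy gives a number 1.1 percentage points higher from compound 2 to compound 3 (within the scatter), so extending the chain at this place, with the ether oxygen kept, recovers none of the effect that compound 1 shows. As far as these compounds go, the gap to the long all-carbon chain stays open, with methoxy in place of butyl, on a saturated chain carbon four bonds along the chain from a nitrogen on an aromatic ring, giving a number 65.4 percentage points lower from compound 1 to compound 3 (beyond the scatter), which shows that the loss seen earlier does not depend only on the shortness of the chain in compound 2. No measurement in hand bears on the reason for this result.

Compound 1 and compound 3 still differ in both chain length and the ether oxygen, so these two features cannot be separated; a hexyl chain and a butyl chain on the same nitrogen would each help to do so. From the compounds shown here alone, how a longer ether chain, or a terminal hydroxyl or amine on the chain, would read in this assay also remains open.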